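Nitrogen substituent on the fused core: isopropyl to cyclopropyl

A few compounds are considered here, and "the series" means these few. Any claim that something is new, unique, unknown or untested is made for them only; others in the source may bear on it.

Three compounds of the series carry a measured value. Compound 1 `CC(C)c1onc(-c2c(Cl)cccc2Cl)c1COc1ccc(-c2nc3cc(C(=O)O)ccc3n2C)cc1` gives 25.8 nM in an assay on Huh-7 cells for agonist activity at Bile acid receptor (Homo sapiens), read by a luciferase reporter; a lower number here means that less compound is needed, a higher number that more compound is needed for the effect. Compound 2 `CC(C)c1onc(-c2c(Cl)cccc2Cl)c1COc1ccc(-c2nc3ccc(C(=O)O)cc3n2C(C)C)cc1`, which carries an isopropyl on the aromatic nitrogen, gives 3.39 nM in this assay. Compound 3 `CCC(CC)n1c(-c2ccc(OCc3c(-c4c(Cl)cccc4Cl)noc3C(C)C)cc2Cl)nc2ccc(C(=O)O)cc21` gives 1.6 nM in this assay. Within these three numbers compound 2 stands second highest: the gap to compound 3 is beyond the scatter, and the gap to compound 1, the furthest of the three, is also beyond the scatter. Among the measured compounds shown here, no pair of measured compounds differs in a single place, so no measured step is at hand.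

Compound 4 `CC(C)c1onc(-c2c(Cl)cccc2Cl)c1COc1ccc(-c2nc3ccc(C(=O)O)cc3n2C2CC2)cc1` has not yet been measured. The change from compound 2 to compound 4 is cyclopropyl in place of isopropyl on an aromatic nitrogen.

The expected step of a 1.3-fold higher number from compound 2 to compound 4 (0.12 log units; within the scatter) is one of no change beyond the scatter, with a slight lean to a higher number. This expectation rests on compound 2 at 3.39 nM and on compound 3 at 1.6 nM. Compound 1 at 25.8 nM stands far higher than both. Compound 4 is therefore estimated at 4.5 nM, with a range from 1.5 nM to 14 nM.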

Compound 4, half-maximal effective concentration: 16.5 nM
For compound 4 the middle estimate is 3.7-fold (0.56 log units) below the measured one, and the stated range ends below it.
By their numbers in this assay, from the lowest: compound 3; then compound 2; then compounds 4 and 1 (each within the scatter of the next).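

In this assay the series now has its first change in a single place, on an aromatic nitrogen of the shared core, with cyclopropyl in place of isopropyl (a 4.9-fold higher number from compound 2 to compound 4 (0.69 log units; beyond the scatter)). The two groups match in their count of 3 carbon heavy atoms and in having no hydrogen-bond donors or acceptors, and they differ in the three-membered ring of cyclopropyl, so the number at this nitrogen can move beyond the scatter with no change in those counts. Nothing at hand accounts for the step.

This reading rests on one pair of compounds on one background. From the compounds shown here alone, whether cyclobutyl, tert-butyl or a longer chain such as n-propyl on the same nitrogen would follow compound 2 or compound 4 stays open, as does whether the step holds with other groups elsewhere on the core.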